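Moving the chlorine on the benzylsulfanyl arm of compound 3

The source may hold more compounds than are shown below. What is called first, only, known or untested is meant among the compounds shown, and "the series" means these compounds.

Measured compounds in a functional assay on the whole organism (artery, strain albino) with Rattus norvegicus as the target, with a stated time of 720 min, at a dose of 10 mg/kg by the oral route; on this read-out higher numbers stand for more inhibition at the one dose given (going by the name of the read-out) and lower numbers for less inhibition:
Compound 1, `COc1ccc(C2N=C(SCc3ccccc3)NC(C)=C2C(=O)Nc2ccc(F)cc2)cc1OC`: 1.5%
Compound 2, `COc1ccc(C2N=C(SCc3cccc(Cl)c3)NC(C)=C2C(=O)Nc2ccc(F)cc2)cc1OC`: 15.5%
Compound 3, `CC1=C(C(=O)Nc2ccc(Br)cc2)C(c2ccc(Cl)cc2Cl)N=C(SCc2ccccc2Cl)N1`: 20.6%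

Compound 3 carries the largest of the three numbers in this assay. Its gap to compound 1 lies beyond the scatter, while its gap to compound 2 lies within it, so compound 3 and compound 2 cannot be told apart on these figures.

Compound 4, `CC1=C(C(=O)Nc2ccc(Br)cc2)C(c2ccc(Cl)cc2Cl)N=C(SCc2ccc(Cl)cc2)N1`, keeps every atom of compound 3 and differs only in one arrangement: 4-chlorophenyl in place of 2-chlorophenyl on a saturated chain carbon bound to a sulfur.

For the measured compounds named here, the one measured step, a number 14 percentage points higher from compound 1 to compound 2 (beyond the scatter), adds a chlorine where there was none; it does not move a chlorine already present. Going by the values given here, no measured pair shows what moving the chlorine from one position of the benzyl ring to another does, so there is no direct precedent for the change from compound 3 to compound 4. The benzylsulfanyl arm seems to matter in this series, but both chlorinated arms already sit at the higher end of the three numbers.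

For compound 4 the step from compound 3 is therefore expected to be small, a number 0.6 percentage points lower from compound 3 to compound 4 (within the scatter), not beyond the scatter in either direction.

Compound 4 is estimated at 20%, with a range from 6% to 34%.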

Compound 4, a percentage reported as inhibition, in the whole organism at one dose (the size of the read-out at that dose, not a potency): 25.8%
Beside the measured number, compound 4's estimate is 5.8 percentage points below it; the range from low to high includes it.
By their numbers in this assay, from the lowest: compound 1; then compounds 2, 3 and 4 (each within the scatter of the next, the first and the last beyond it).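

In this assay, for the compounds shown here, the change from 2-chlorobenzyl to 4-chlorobenzyl gives a number 5.2 percentage points higher from compound 3 to compound 4 (within the scatter), the only measured step here that relocates a chlorine on this arm rather than adding one. With the atoms unchanged, the two arrangements cannot be told apart at this one dose, so on these figures the read-out does not distinguish between 2-chlorophenyl and 4-chlorophenyl on the saturated chain carbon bound to a sulfur. Nothing available here accounts for the size of this step.

The compounds shown leave open whether a methoxy group or a nitrile in place of the chlorine, or a longer chain between the sulfur and the aromatic ring, would move the read-out beyond the scatter. As far as these compounds go, it also remains open whether the same chlorine move would behave alike on the core of compound 1.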